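The compounds below may be only part of what the source reports. "The series", "measured", "known", "first", "only" and "open" are said of these compounds alone.

Among the compounds with values here, compound 1, `Cc1ccc(-c2ccc(O[C@H]3O[C@H](CO)[C@@H](O)[C@H](O)[C@@H]3O)c(Cl)c2)cc1`, is the only compound here with a number in hand. In a physicochemical assay for lipophilicity, read by LC-MS, measured as octanol-water partition, with a stated time of 2 h, at pH 7.4, tested at 1 uM (on this read-out higher numbers stand for higher lipophilicity and lower numbers for lower lipophilicity), compound 1 gives 3.3. Compound 2, `OC[C@H]1O[C@H](Oc2ccc(-c3ccc(Cl)c(C(F)(F)F)c3)cc2Cl)[C@@H](O)[C@@H](O)[C@@H]1O`, was also tested in this assay, where compound 2 gives "not determined" (no result reported), so no result was reported for it. Compound 3, `OC[C@H]1O[C@H](Oc2ccc(-c3ccccc3)cc2Cl)[C@@H](O)[C@@H](O)[C@@H]1O`, is the one still to be measured, and it differs from compound 1 only by hydrogen in place of methyl on an aromatic carbon. Within the data shown here, no measured pair of compounds shows this kind of step, so its size rests on expectation: the step is expected to be a number 0.50 log units lower from compound 1 to compound 3 (beyond the scatter), a modest drop in this assay just beyond the usual scatter. Compound 3 is therefore estimated at 2.8, between 2.4 and 3.2.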

Compound 3, distribution coefficient: 2.6
Compound 3: middle estimate off by 0.20 log units, on the high side; measured number inside the range.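

In this assay, within the data shown here, going from 4-methylphenyl to phenyl gives a number 0.70 log units lower from compound 1 to compound 3 (beyond the scatter), the first measured step at this position. It shows that losing this one carbon, on an aromatic carbon para to a large group, shifts the read-out by a modest amount that repeat measurements alone would not explain. No available evidence accounts for the size of this step.

Still open, as far as these compounds go, is how a larger group at this position would read, such as an ethyl group, a methoxy group or an amine. It is also unknown whether this step keeps its size when other parts of the molecule change.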